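The source may hold more compounds than are shown below. What is called first, only, known or untested is meant among the compounds shown, and "the series" means these compounds.

Working notes on the series.

Compound 1 `COc1c(OC)c(OC(C)=O)c2c(OC)cccc2c1OC(C)=O` gives 2.43 in a physicochemical assay for lipophilicity; a higher number here means a more lipophilic compound, a lower number a more polar compound. Compound 3 `COc1c(OC)c(OC(C)=O)c2c(C)cccc2c1OC(C)=O` gives 2.8 in this assay, and the change methyl in place of methoxy on an aromatic carbon made the step of a number 0.37 log units higher from compound 1 to compound 3 (beyond the scatter). Compound 2 `COc1ccc2c(OC(=O)C(C)(C)C)c(OC)c(OC)c(OC(=O)C(C)(C)C)c2c1` gives 5.4 in this assay, the highest of the three; the difference between its core and that of compound 1 is not broken down here.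

Compound 4 `COc1c(OC)c(OC(=O)C(C)(C)C)c2cc(C)ccc2c1OC(=O)C(C)(C)C` awaits measurement. It differs from compound 2 by methyl in place of methoxy on an aromatic carbon. The place is not identical to the earlier one: there the methyl is ortho and meta to a fused ring, here meta and para, so it is the same kind of change rather than the same change. Because a number 0.37 log units higher from compound 1 to compound 3 (beyond the scatter), the expected step is a number 0.35 log units higher from compound 2 to compound 4 (beyond the scatter), resting on that single earlier pair. Compound 4 is therefore estimated at 5.75, between 5.3 and 6.2.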

Compound 4, partition coefficient: 6.1
Estimate against measurement, compound 4: 0.35 log units below, within the range that was stated.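

In this assay the change of methyl in place of methoxy on an aromatic carbon goes the same way on both cores, with a number 0.37 log units higher from compound 1 to compound 3 (beyond the scatter) and a number 0.70 log units higher from compound 2 to compound 4 (beyond the scatter) in the second pair. These are two pairs only, and the place differs between them, meta and para to a fused ring in the new pair, so the direction carries over here but no fixed size of step or rule for other cores is shown. Nothing measured here bears on why the two steps differ in size.

The compounds shown leave open whether an amine, a carboxylic acid or a longer chain on that aromatic carbon would move the number the same way. They also leave open whether methyl in place of methoxy at one identical place gives a similar step on both cores.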